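A few compounds are considered here, and "the series" means these few. Any claim that something is new, unique, unknown or untested is made for them only; others in the source may bear on it.

Of the compounds shown here, three have so far been measured in a functional assay on IGROV-1 cells (Homo sapiens) for cytotoxicity, read by sulforhodamine B assay, with a stated time of 48 h, tested at 1 uM; on this read-out lower numbers stand for a stronger effect and higher numbers for a weaker effect at the one concentration tested. Compound 1 `COc1cc(-c2cc(/C=C/C(=O)c3ccc(N)cc3)[nH]n2)cc(OC)c1OC` gives 100% in this assay. Compound 2 `COc1ccc(C(=O)/C=C/c2cc(-c3cc(OC)c(OC)c(OC)c3)n[nH]2)cc1OC` gives 96%, and compound 3 `COc1ccc(C(=O)/C=C/c2cc(-c3cc(OC)c(OC)c(OC)c3)n[nH]2)cc1` gives 101%. The step from compound 1 to compound 2 is a number 4 percentage points lower from compound 1 to compound 2 (within the scatter), and the step from compound 1 to compound 3 is a number 1 percentage points higher from compound 1 to compound 3 (within the scatter). All three numbers sit within the scatter of one another, so none of the three compounds can be called more or less active than the others at the single concentration tested.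

Compound 4 `COc1ccc(-c2cc(/C=C/C(=O)c3ccc(N)cc3)[nH]n2)cc1OC` has not yet been measured. It differs from compound 1 by hydrogen in place of methoxy on an aromatic carbon. The same kind of change has already been made between two measured compounds: compound 3 differs from compound 2 by hydrogen in place of methoxy on an aromatic carbon, and there the step was a number 5 percentage points higher from compound 2 to compound 3 (within the scatter). The two places are not identical in every word: in compound 1 the carbon that loses its methoxy is also meta to a methoxy group, while in compound 2 it is not. The cores of compound 1 and compound 2 differ as well, by 4-aminophenyl in place of 3,4-dimethoxyphenyl on a carbonyl carbon.

Compound 4 is expected to give about 99% in this assay, with a range from 90% to 108%. The expected step from compound 1 to compound 4 is a number 1 percentage points lower from compound 1 to compound 4 (within the scatter), an estimate resting on the fact that the measured step of a number 5 percentage points higher from compound 2 to compound 3 (within the scatter) lay within the scatter and that compound 1 itself gives 100%.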

Compound 4, a percentage reported as activity, at one concentration (the size of the read-out at that concentration, not a potency): 100%
The estimate for compound 4 lay 1 percentage points below the measured number, within the range that was stated.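

Hydrogen in place of methoxy on an aromatic carbon gives no change at the digits printed from compound 1 to compound 4 (within the scatter) in this assay. Set beside the same change on the other core, the two steps cannot be told apart: the same change on two cores in this assay, a number 5 percentage points higher (within the scatter) from compound 2 to compound 3 and no change at the digits printed (within the scatter) from compound 1 to compound 4, 5 percentage points apart, within the scatter of two such steps

Going by these compounds alone, in this small set, therefore, the change carries from one core to the other without a step that stands out from the scatter, but this agreement rests on just two steps, both within the scatter, at the one concentration tested, so it shows only that neither core gives a readable step here and does not show that the change would behave alike on a core where the read-out stands well away from these numbers.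

The compounds shown leave open what other groups would give on the same aromatic carbon, such as a hydroxy group, a fluorine atom or a longer chain like ethoxy, and what a carboxylic acid or an amide would give in place of the amino group of compound 1. They also leave open how the methoxy and hydrogen pairs would compare at any other concentration.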